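Changing the group on the sulfonyl sulfur

A few compounds are considered here, and "the series" means these few. Any claim that something is new, unique, unknown or untested is made for them only; others in the source may bear on it.

In a physicochemical assay for solubility, in phosphate buffer, with a stated time of 24 h, at pH 7.4, tested at 100 uM (a lower number here means a less soluble compound, a higher number a more soluble compound), compound 2 (`CN1CCC(S(=O)(=O)c2ccc(CNC(=O)N3Cc4ccncc4C3)cc2)CC1`) gives 240000 nM and compound 1 (`O=C(NCc1ccc(S(=O)(=O)C2CCCOC2)cc1)N1Cc2ccncc2C1`) gives 208000 nM on the same core. These two numbers lie within the scatter of each other, so compound 2 stands level with compound 1 on the only data available.

Compound 3 (`O=C(NCc1ccc(S(=O)(=O)N2CCC(O)CC2)cc1)N1Cc2ccncc2C1`) carries 4-hydroxypiperidin-1-yl in place of 1-methylpiperidin-4-yl on a sulfonyl sulfur. The counted difference reads: 4-hydroxypiperidin-1-yl in place of 1-methylpiperidin-4-yl on a sulfonyl sulfur.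

Going by the values given here, one measured step bears on this change: a 1.2-fold higher number from compound 1 to compound 2 (0.06 log units; within the scatter) for 1-methylpiperidin-4-yl in place of oxan-3-yl at that same place. Among the compounds with values here, no measured compound carries 4-hydroxypiperidin-1-yl, so this single step within the scatter is thin support, and the range is kept wide.

The expected step is a 1.3-fold lower number from compound 2 to compound 3 (0.12 log units; within the scatter) in this assay and is thus expected to be none beyond the scatter. The estimate for compound 3 is 180000 nM in this assay with an expected range from 85000 nM to 290000 nM for the coming measurement.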

Compound 3, solubility: 174000 nM
Beside the measured number, compound 3's estimate is 1.0-fold (0.01 log units) above it; the measured number falls inside the stated range.
By their numbers in this assay, from the lowest: compounds 3, 1 and 2 (each within the scatter of the next).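

The group on a sulfonyl sulfur now has a third member, 4-hydroxypiperidin-1-yl, and this assay reads a 1.4-fold lower number from compound 2 to compound 3 (0.14 log units; within the scatter) against 1-methylpiperidin-4-yl and a 1.2-fold lower number from compound 1 to compound 3 (0.08 log units; within the scatter) against oxan-3-yl. The group that enters carries a hydrogen-bond donor and an oxygen, while the group that leaves carries no hydrogen-bond donor, yet this change gives no separation beyond the scatter, and the three compounds stand level in this read-out. No measured evidence on the series accounts for this result.

All three groups shown are six-membered non-aromatic rings, so it remains open whether a group of another kind on the sulfonyl sulfur, such as a carboxylic acid, a primary amine or an open alkyl chain, would stay level with them in this assay. The compounds shown also leave open whether these three groups would stay level on any other read-out or on any core other than the shared core.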